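The compounds below may be only part of what the source reports. "The series", "measured", "known", "first", "only" and "open" are said of these compounds alone.

In an assay on isolated protein for inhibition of G protein-coupled receptor kinase 6 (Homo sapiens), read by scintillation counting, radiometric assay and 33P incorporation, with a stated time of 80 min, in the presence of a further agent that is not named here (on this read-out lower numbers stand for stronger inhibition and higher numbers for weaker inhibition), compound 3 `CCc1cc(Nc2nc(N[C@@H](C)c3ccc(F)cn3)nc3cccc(F)c23)n[nH]1` gives 29 nM, the second highest of the three numbers. Compound 2 `CCc1cc(Nc2nc(N[C@@H](C)c3ccc(F)cn3)nc3cccc(C)c23)n[nH]1` gives 11 nM, and the step is a 2.6-fold higher number from compound 2 to compound 3 (0.42 log units; beyond the scatter). Compound 1 `CCn1cnc(Nc2nc(N[C@@H](C)c3ccc(F)cn3)nc3cccc(F)c23)c1` gives 280 nM, and the step is a 9.7-fold lower number from compound 1 to compound 3 (0.98 log units; beyond the scatter). Compound 4 `CCc1cc(Nc2nc(N[C@@H](C)c3ncc(F)cn3)nc3cccc(F)c23)n[nH]1` differs from compound 3 by 5-fluoropyrimidin-2-yl in place of 5-fluoropyridin-2-yl on a saturated chain carbon bound to a nitrogen on an aromatic ring and a saturated chain carbon. Among the measured compounds shown here, neither measured step touches this part of the molecule: one exchanges a group on a nitrogen on an aromatic ring, the other a group on an aromatic carbon, so no measured step bears on the change. With nothing to support a shift in this assay, compound 4 is expected to give a number close to that of compound 3. The expected step is a 1.2-fold higher number from compound 3 to compound 4 (0.08 log units; within the scatter). For compound 4 the estimate is 35 nM, with a range from 12 nM to 100 nM.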

Compound 4, half-maximal inhibitory concentration: 230 nM
Estimate against measurement, compound 4: 6.6-fold (0.82 log units) below, and the stated range ends below it.
By their numbers in this assay, from the lowest: compound 2; then compound 3; then compounds 4 and 1 (each within the scatter of the next).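

Among the compounds shown here, the aromatic ring on the saturated chain carbon proves to be a sensitive place in the molecule, one the earlier steps did not touch. With 5-fluoropyrimidin-2-yl in place of 5-fluoropyridin-2-yl, the change of one ring atom gives a 7.9-fold higher number from compound 3 to compound 4 (0.90 log units; beyond the scatter) and so weaker inhibition, although the heavy-atom count stays the same. No measurement at hand accounts for this loss. The compounds shown leave open whether the same exchange costs as much in compound 2, which carries methyl in place of fluoro, and how a plain phenyl ring would read at this place.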